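Series notes: loss of a propyl chain on the core

The source may hold more compounds than are shown below. What is called first, only, known or untested is meant among the compounds shown, and "the series" means these compounds.

Measured compounds, all in a functional assay for inhibition, with Homo sapiens as the target; on this read-out lower numbers stand for stronger inhibition and higher numbers for weaker inhibition:
compound 1 `CCCc1ncn2c(O)nncc12` gives > 48000 nM, a limit of the assay.
compound 2 `CCCc1nc(C)c2cnnc(SC)n12` gives > 48000 nM, a limit of the assay.
compound 3 `CCCc1nnc(SC)n2c(CCC)nc(C)c12` gives > 48000 nM, a limit of the assay.

Every value in this assay is a limit and not a number; all three sit at the limit of > 48000 nM in this assay, at which 3 of the 3 values shown sit. The step from compound 3 to compound 2 is a step that the two limits leave unreadable from compound 3 to compound 2, its size not readable from the two limits. The change there is hydrogen in place of propyl on an aromatic carbon.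

Compound 4 `Oc1nncc2cncn12` is not yet measured. It differs from compound 1 by hydrogen in place of propyl on an aromatic carbon. This is the same kind of change as from compound 3 to compound 2, not the same: there the propyl leaves a six-membered aromatic ring with 3 nitrogen, ortho to a fused ring, two atoms from the ring nitrogen, para to a methylsulfanyl group; here it leaves a five-membered aromatic ring with 2 nitrogen, two ring bonds from the ring nitrogen. The difference between the core of compound 1 and the core of compound 3 is not broken down here.

Within the data shown here, for compound 4 the step from compound 1 is expected to be a step that the limit leaves unreadable from compound 1 to compound 4, resting only on compound 1 giving > 48000 nM and on the series sitting wholly at the limit of > 48000 nM in this assay, at which 3 of the 3 values shown sit, so that no measured step gives a direction. Compound 4 is therefore estimated at 100000 nM, between 30000 nM and 400000 nM, and most likely a limit again.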

Compound 4, half-maximal inhibitory concentration: > 48000 nM
Compound 4: no number, only a limit; the forecaster's own chance of this, stated with the estimate: 90%; the middle value lies beyond the limit too.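

In this assay no step can be read from compound 1 to compound 4 because both compounds sit at the same limit of the assay, which is not a number: the limit of > 48000 nM in this assay, at which 4 of the 4 values shown sit.

The compounds shown leave open whether hydrogen in place of propyl on an aromatic carbon changes inhibition on either core, and how far any of the four compounds lies beyond that limit.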